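This account rests on a few compounds, and the source may have more. Where it says the series, first, only, none or still open, it means among the compounds named here.

Measured so far:
- compound 1, `CCOC(=O)[C@@H](N)CCC(=O)NCCSC(=O)C(C)(C)C`: 0.167 h
- compound 2, `CCCOC(=O)[C@@H](N)CCC(=O)NCCSC(C)=O`: 0.167 h

In an ADME assay on isolated protein for metabolic stability, with Cocaine esterase (Homo sapiens) as the target (on this read-out higher numbers stand for a longer-lived compound and lower numbers for a shorter-lived compound), compound 1 gives 0.167 h, and compound 2 gives 0.167 h, level with compound 1 at the digits shown, within the scatter. Compound 3, `CCCOC(=O)[C@@H](N)CCC(=O)NCCSC(=O)C(C)(C)C`, is still to be measured. It differs from compound 2 by tert-butyl in place of methyl on a carbonyl carbon. Compound 1 already carries the ((tert-butyl)carbonyl)sulfanyl group and gives 0.167 h, so no step beyond the scatter is expected in this assay. The expected step from compound 2 to compound 3 is a 1.0-fold higher number from compound 2 to compound 3 (0.01 log units; within the scatter). Compound 3 is estimated at 0.17 h, expected range 0.08 h to 0.4 h.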

Compound 3, half-life: 0.167 h
For compound 3 the middle estimate is 1.0-fold (0.01 log units) above the measured one; measured number inside the range.
By their numbers in this assay, from the lowest: compounds 1, 2 and 3 (each within the scatter of the next).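

Tert-butyl in place of methyl on a carbonyl carbon whose other neighbour is sulfur gives no change at the digits printed from compound 2 to compound 3 (within the scatter) in this assay, the first direct reading of this change. Methyl in place of hydrogen on a saturated chain carbon, two bonds along the chain from an oxygen next to a carbonyl group, gives no change at the digits printed from compound 1 to compound 3 (within the scatter) with the ((tert-butyl)carbonyl)sulfanyl group held the same. No measurement at hand offers an explanation for either step.

Still open, on these data alone, is whether a carboxylic acid in place of the ester, or a phenyl ring on the same carbonyl carbon, would separate from these compounds in this assay on the same read-out.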